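A few compounds are considered here, and "the series" means these few. Any claim that something is new, unique, unknown or untested is made for them only; others in the source may bear on it.

Measured so far in a functional assay for inhibition, tested at 20 ug/mL; a lower number here means a weaker effect, a higher number a stronger effect of the compound at the concentration tested:
- compound 1 `COc1cccc(-c2cc(-c3cc(C(C)C)c(O)cc3C)[nH]c(=O)c2C#N)c1`: 22%
- compound 2 `Cc1cc(O)c(C(C)C)cc1-c1cc(-c2cccs2)c(C#N)c(=O)[nH]1`: 26%

Compound 1 holds the lowest of the two numbers in this assay; its nearest neighbour is compound 2, and the step of a number 4 percentage points higher from compound 1 to compound 2 (within the scatter) lies within the scatter, so the two values are not distinguishable here.

Compound 3 `Cc1cc(O)c(C(C)C)cc1-c1cc(-c2ccc(N(C)C)cc2)c(C#N)c(=O)[nH]1` has not yet been measured in this assay. It differs from compound 1 as follows: 4-(dimethylamino)phenyl in place of 3-methoxyphenyl on an aromatic carbon.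

For the measured compounds named here, no measured step covers this particular change. Going by the values given here, the only step available, the swap to thiophen-2-yl at the same aromatic carbon from compound 1 to compound 2, stayed within the scatter. On that basis nothing beyond the scatter is expected from the present replacement either, though the evidence is thin.

For compound 3 the expected step is a number 3 percentage points higher from compound 1 to compound 3 (within the scatter). Compound 3 is estimated at 25%, with a range from 10% to 45%.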

Compound 3, a percentage reported as inhibition, at one concentration (the size of the read-out at that concentration, not a potency): 30%
Beside the measured number, compound 3's estimate is 5 percentage points below it, within the range that was stated.
By their numbers in this assay, from the lowest: compounds 1, 2 and 3 (each within the scatter of the next).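

In this assay, a third group on this aromatic carbon, opposite the ring nitrogen, stays within the scatter: a number 8 percentage points higher from compound 1 to compound 3 (within the scatter) and a number 4 percentage points higher from compound 2 to compound 3 (within the scatter). The 4-(dimethylamino)phenyl group, with a nitrogen-bearing substituent in a different arrangement from the oxygen-bearing 3-methoxyphenyl, cannot be told apart from either 3-methoxyphenyl or thiophen-2-yl at this single concentration. No supporting data bear on why these groups read alike.

As far as these compounds go, whether any group at this position can move the read-out beyond the scatter remains open. A carboxylic acid, a saturated amine such as piperidin-1-yl or a plain alkyl chain in place of the aromatic group would show whether an aromatic ring matters here at all.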